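The source may report more compounds than this note shows. Statements on the series, on what has been measured and on what is new or still open speak of the compounds shown alone.

In an ADME assay on HeLa cells (Homo sapiens) for cytotoxicity, read by MTT assay, with a stated time of 24 h (a higher number here means a weaker inhibitor, a lower number a stronger inhibitor), compound 1 `CN(C)C(=S)SC(=S)N1CCCC1` gives 3090000 nM, and compound 3 `CCCCN1CCN(C(=S)SC(=S)N(C)C)CC1` gives 4100000 nM; these two numbers sit within the scatter of each other, so neither can be set apart from the other. Compound 2 `CN(C)C(=S)SC(=S)N1CCCCCC1` reaches only a limit in this assay, reported as > 5000000 nM, which is a limit of the assay and not a number. Compound 4 `CN(C)C(=S)SC(=S)N1CCN(c2ncccn2)CC1` has not yet been measured in this assay. It differs from compound 3 in one place: pyrimidin-2-yl in place of butyl on an amine nitrogen in a ring. No pair of measured compounds shows a step of this kind, so its size cannot be read from the numbers shown. The expected step in this assay is a 1.1-fold higher number from compound 3 to compound 4 (0.04 log units; within the scatter), which is not beyond the scatter. Compound 4 is therefore estimated at 4500000 nM, with a range from 1500000 nM to 10000000 nM.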

Compound 4, half-maximal inhibitory concentration: > 5000000 nM
Compound 4 ended at the assay's limit (the forecaster's own chance of this, stated with the estimate: 35%); at least 1.1-fold (0.04 log units) between middle value and limit.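

At this amine nitrogen in a ring, pyrimidin-2-yl in place of butyl gives an at least 1.2-fold higher number from compound 3 to compound 4 (0.08 log units; that floor lies within the scatter) in this assay. Compound 4 stands at > 5000000 nM, which is a limit of the assay and not a number. The change therefore brings no lower number at this position, and the true size of the step cannot be read: the limit of > 5000000 nM in this assay, at which 2 of the 4 values shown sit.

The compounds shown leave open whether a chain ending in a carboxylic acid or an amine on this nitrogen would give a number set apart from compound 3.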